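This account rests on a few compounds, and the source may have more. Where it says the series, first, only, none or still open, it means among the compounds named here.

Measured so far in a physicochemical assay for solubility, read by HPLC, at pH 7.4; on this read-out lower numbers stand for lower solubility and higher numbers for higher solubility:
compound 1 `CCCCCOCc1cc(=O)c2cc(C(F)(F)F)ccc2[nH]1` gives 15000 nM.
compound 2 `CCOCCCCc1cc(=O)c2cc(C(F)(F)F)ccc2[nH]1` reaches only a limit of the assay, > 200000 nM.
compound 3 `CCCCCOCc1[nH]c2ccc([N+](=O)[O-])cc2c(=O)c1C(=O)OCC` gives 15000 nM.

The step of an at least 13-fold higher number from compound 1 to compound 2 (1.12 log units; beyond the scatter) belongs to the change (3-ethoxypropyl in place of pentyloxy on a saturated chain carbon bound to an aromatic carbon); its size is bounded by the limit of > 200000 nM in this assay, at which 1 of the 3 values shown sits. Compound 3 stands level with compound 1, with no change at the digits shown. The difference between the core of compound 3 and the core of compound 1 is not broken down here. Compound 4 `CCOCCCCc1[nH]c2ccc([N+](=O)[O-])cc2c(=O)c1C(=O)OCC` differs from compound 3 by 3-ethoxypropyl in place of pentyloxy on a saturated chain carbon bound to an aromatic carbon, the same change as between compound 1 and compound 2. A step of similar size is expected because compound 3 starts at 15000 nM, namely a 13-fold higher number from compound 3 to compound 4 (1.12 log units; beyond the scatter). There is a fair chance that compound 4 is again expected to reach only a limit of the assay. Compound 4 is estimated at 200000 nM, expected between 60000 nM and 600000 nM.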

Compound 4, solubility: 5000 nM
Beside the measured number, compound 4's estimate is 40-fold (1.60 log units) above it; measured number below the stated range.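

In this assay the same change moves the read-out in opposite directions on the two cores: a 3.0-fold lower number from compound 3 to compound 4 (0.48 log units; beyond the scatter), against an at least 13-fold higher number from compound 1 to compound 2 (1.12 log units; beyond the scatter). Compound 2 gives > 200000 nM, which is a limit of the assay and not a number. The change therefore does not carry over from the core of compound 1 to the core of compound 3 in either direction or size, but one pair per core gives no rule for any other core.

The compounds shown leave open whether the nitro group, the ethyl ester or both go with the reversed step. Also open, on these data alone, is how a carboxylic acid or an amine would read in this assay.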